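A few compounds are considered here, and "the series" means these few. Any claim that something is new, unique, unknown or untested is made for them only; others in the source may bear on it.

Compound 1 `C=CC1=C(C(=O)NCCCCC)C(c2ccc(Cl)c(Cl)c2)OC1` gives > 100000 nM in a functional assay on QGY7701 cells (Homo sapiens) for cytotoxicity, read by MTT assay, with a stated time of 24 h; a higher number here means a weaker inhibitor, a lower number a stronger inhibitor.
Compound 2 `C=CC1=C(C(=O)Nc2ccc(OCC)cc2)C(c2ccc(OC)cc2)OC1` gives > 100000 nM in this assay.
Compound 3 `C=CC1=C(C(=O)Nc2ccc(OCC)cc2)C(c2ccc(F)cc2)OC1` gives 61600 nM in this assay.

In this assay compound 2 gives > 100000 nM, which is a limit of the assay and not a number. The same is true of compound 1, whose value in this assay is > 100000 nM, a limit. Within the data shown here, compound 3 is the only one of the three with a real number, and the step of an at least 1.6-fold lower number from compound 2 to compound 3 (0.21 log units; that floor lies within the scatter) is the only measured step in this set; it concerns a change on the aromatic ring, not the amide side, so it does not bear directly on the change considered here. the limit of > 100000 nM in this assay, at which 2 of the 3 values shown sit, frames where compound 2 stands.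

Compound 4 `C=CC1=C(C(=O)NCC(C)C)C(c2ccc(OC)cc2)OC1` differs from compound 2 in one place: isobutyl in place of 4-ethoxyphenyl on an amide-type nitrogen. Compound 1 also carries a plain alkyl chain on the amide-type nitrogen and sits at the limit, so the alkyl amide of compound 4 offers no measured ground to expect a real number. The step of a number no higher from compound 2 to compound 4 (the limit leaves the size open) is therefore expected to be none beyond the scatter, with compound 4 most likely again at the limit. The estimate for compound 4 in this assay is 100000 nM, with a range from 40000 nM to 300000 nM.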

Compound 4, half-maximal inhibitory concentration: > 100000 nM
Compound 4 ended at the assay's limit; the forecaster's own chance of this, stated with the estimate: 70%; the middle value sits exactly at the limit.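

Compound 2 and compound 4 both end at a limit of this assay and not at a number, so the step from 4-ethoxyphenyl to isobutyl on the amide-type nitrogen cannot be read: the limit of > 100000 nM in this assay, at which 3 of the 4 values shown sit.

The compounds shown leave open whether either of these two groups gives the lower number, and by how much.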